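Thioether for ether on the diamino core

The source may hold more compounds than are shown below. What is called first, only, known or untested is meant among the compounds shown, and "the series" means these compounds.

Compound 1 `Nc1cc(N)c2nc(-c3ccccc3)c(Oc3ccc(Cl)c(Cl)c3)nc2c1` is recorded in a functional assay on A498 cells (Homo sapiens) for inhibition, read by sulforhodamine B assay, with a stated time of 48 h (a lower number here means that less compound is tolerated, a higher number that more compound is tolerated), only as the limit < 100000 nM and not as a number. Compound 2 `CCOC(=O)[C@H](CCC(=O)O)NC(=O)c1ccc(Sc2nc3cc(N)cc(N)c3nc2-c2ccccc2)cc1` likewise reaches only the limit < 100000 nM in this assay. Compound 3 `COc1cc(CNc2nc3cc(N)cc(N)c3nc2-c2ccccc2)cc(OC)c1OC` gives 33900 nM in this assay. Going by the values given here, two of the three values therefore sit at the limit (the limit of < 100000 nM in this assay, at which 2 of the 3 values shown sit), and compound 1 stands among them, with no step between measured compounds to draw on. Compound 4 `Nc1cc(N)c2nc(-c3ccccc3)c(Sc3ccc(Cl)c(Cl)c3)nc2c1` differs from compound 1 by (3,4-dichlorophenyl)sulfanyl in place of 3,4-dichlorophenoxy on an aromatic carbon. Among the compounds with values here, no step of this kind has been measured. The change is expected to stay within the scatter, so the step from compound 1 to compound 4 is expected at a step that the limit leaves unreadable from compound 1 to compound 4. Compound 4 is estimated at 30000 nM, between 5000 nM and 100000 nM.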

Compound 4, concentration lethal to 50% of the cells: 57500 nM
Compound 4: middle estimate off by 1.9-fold (0.28 log units), on the low side; the measured number falls inside the stated range.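

No step can be read from compound 1 to compound 4, since the value of compound 1 is only a limit: the limit of < 100000 nM in this assay, at which 2 of the 4 values shown sit.

As far as these compounds go, whether (3,4-dichlorophenyl)sulfanyl in place of 3,4-dichlorophenoxy changes the lethal concentration beyond the usual scatter remains open.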